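Acetyl for Methyl on the Ring Amine of Compound 1

The source may hold more compounds than are shown below. What is called first, only, known or untested is meant among the compounds shown, and "the series" means these compounds.

Compound 1 `CN1CCc2oc(=O)n(C(=O)NCCCCc3ccccc3)c2C1` gives 516 nM in an assay on HEK293 cells for inhibition of acid ceramidase (Homo sapiens), read by fluorescence, with stated times of 10 min and 3 h; a lower number here means a stronger inhibitor, a higher number a weaker inhibitor.
Compound 2 `O=C(NCCCCc1ccccc1)n1c(=O)oc2cc(C3CCOCC3)ccc21` gives 68 nM in this assay.

Of the two measured values, compound 1 has the highest number; compound 2 sits well below it, a gap beyond the usual scatter. Compound 3 `CC(=O)N1CCc2oc(=O)n(C(=O)NCCCCc3ccccc3)c2C1` differs from compound 1 in one place: acetyl in place of methyl on an amine nitrogen in a ring. For the measured compounds named here, no measured pair shows this change, so the expectation rests on the change itself. In this assay the step of a 1.5-fold lower number from compound 1 to compound 3 (0.17 log units; within the scatter) is expected to be small, toward a lower number but hardly beyond the scatter. Compound 3 is therefore estimated at 350 nM, within 100 nM to 1500 nM.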

Compound 3, half-maximal inhibitory concentration: 293 nM
Compound 3: the middle estimate sits 1.2-fold (0.08 log units) above what was measured, within the range that was stated.
By their numbers in this assay, from the lowest: compound 2; then compounds 3 and 1 (each within the scatter of the next).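

In this assay the amine nitrogen in the ring accepts acetyl in place of methyl with little effect: the step is a 1.8-fold lower number from compound 1 to compound 3 (0.25 log units; within the scatter) and does not separate the two compounds. This single change, which brings in one hydrogen-bond acceptor, therefore leaves the number within the scatter. Nothing measured here bears on why the number holds.

On these data alone, whether a benzoyl group, a methanesulfonyl group or a bare hydrogen on this nitrogen would move the number beyond the scatter remains open.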